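A few compounds are considered here, and "the series" means these few. Any claim that something is new, unique, unknown or untested is made for them only; others in the source may bear on it.

Measured in an in vitro ADME assay on microsomes from liver (Simiiformes); a lower number here means that the compound disappears faster, a higher number that the compound lasts longer:
- compound 1 `COCc1cc(CCCOc2c(C)cc(-c3noc(C(F)(F)F)n3)cc2C)on1`: 1.58 h
- compound 2 `Cc1cc(-c2noc(C(F)(F)F)n2)cc(C)c1OCCCc1cc(CS(C)(=O)=O)no1`: > 2.5 h, a limit of the assay and not a number

Compound 2 has no exact half-life; its place is the limit of > 2.5 h in this assay, at which 1 of the 2 values shown sits.

The next change leads to compound 3 `Cc1ccc(CCCOc2c(C)cc(-c3noc(C(F)(F)F)n3)cc2C)cn1`: 6-methylpyridin-3-yl in place of 3-((methylsulfonyl)methyl)-1,2-oxazol-5-yl on a saturated chain carbon, three bonds along the chain from an oxygen on an aromatic ring. In words, this is 6-methylpyridin-3-yl in place of 3-((methylsulfonyl)methyl)-1,2-oxazol-5-yl on a saturated chain carbon, three bonds along the chain from an oxygen on an aromatic ring.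

Going by the values given here, only one measured step bears on this, and only loosely: an at least 1.5-fold higher number from compound 1 to compound 2 (0.19 log units; that floor lies within the scatter), with methylsulfonyl in place of methoxy on a saturated chain carbon bound to an aromatic carbon. Among the compounds with values here, that step keeps the five-membered aromatic ring, whereas the new change removes it, so no measured step tests this exchange. With the methylsulfonyl gone as well, the expectation is a half-life nearer that of compound 1, at 1.58 h. A lower number is therefore expected, with an estimated at least 1.7-fold lower number from compound 2 to compound 3 (0.25 log units; that floor lies within the scatter). For compound 3 the expected half-life is 1.4 h, with an estimated range of 0.6 h to 2.5 h.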

Compound 3, half-life: 1.97 h
Compound 3: middle estimate off by 1.4-fold (0.15 log units), on the low side; measured number inside the range.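

In this assay, the place on a saturated chain carbon, three bonds along the chain from an oxygen on an aromatic ring, now holds a six-membered aromatic ring, and 6-methylpyridin-3-yl in place of 3-(methoxymethyl)-1,2-oxazol-5-yl gives a 1.2-fold higher number from compound 1 to compound 3 (0.10 log units; within the scatter), so the half-lives of these two compounds cannot be told apart and the five-membered ring is not needed for a half-life of this size. Against the 3-((methylsulfonyl)methyl)-1,2-oxazol-5-yl group, the same exchange gives an at least 1.2-fold lower number from compound 2 to compound 3 (0.10 log units; that floor lies within the scatter), which does not separate these two compounds either. Compound 2 has only a limit of the assay, and the true size of that step stays unknown for that reason: the limit of > 2.5 h in this assay, at which 1 of the 3 values shown sits.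

Going by these compounds, whether the methyl group of 6-methylpyridin-3-yl matters to the half-life remains open, as does how a plain pyridin-3-yl or a phenyl ring would read at this place. Also open, on these data alone, is whether a methylsulfonyl group carried on the six-membered ring, or a morpholine in its stead, would change the half-life of compound 3.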